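A few compounds are considered here, and "the series" means these few. Any claim that something is new, unique, unknown or untested is made for them only; others in the source may bear on it.

Measured compounds:
compound 1, `CCOC(=O)c1cc(-c2cc(OC)c(OC)c(OC)c2)c(-c2ccc(OC)cc2)s1`, 9760 nM;
compound 2, `CCOC(=O)c1cc(-c2cc(OC)c(OC)c(OC)c2)c(-c2cccc(Br)c2)s1`, > 100000 nM, a limit of the assay rather than a number;
compound 3, `CCOC(=O)c1cc(-c2cc(OC)c(OC)c(OC)c2)c(-c2ccc3ccccc3c2)s1`, 4340 nM.

In a functional assay on SGC-7901 cells (Homo sapiens) for antiproliferative activity, read by MTT assay, with a stated time of 72 h (a lower number here means a stronger inhibitor, a higher number a weaker inhibitor), compound 1 gives 9760 nM, the highest of the two numbers shown. The value for compound 2 is only a limit of the assay (the limit of > 100000 nM in this assay, at which 1 of the 3 values shown sits). The nearest number belongs to compound 3, with a 2.2-fold lower number from compound 1 to compound 3 (0.35 log units; beyond the scatter). The other recorded step, an at least 10-fold higher number from compound 1 to compound 2 (1.01 log units; beyond the scatter), runs the opposite way. Compound 4, `CCOC(=O)c1cc(-c2cc(OC)c(OC)c(OC)c2)c(-c2ccc(OC)c(OCc3ccccc3)c2)s1`, has not been measured. It differs from compound 1 by benzyloxy in place of hydrogen on an aromatic carbon. For the measured compounds named here, no measured step covers exactly this change; the closest is the growth of the aryl group from compound 1 to compound 3, which gave a 2.2-fold lower number from compound 1 to compound 3 (0.35 log units; beyond the scatter), while the loss of the methoxy group in compound 2 gave an at least 10-fold higher number from compound 1 to compound 2 (1.01 log units; beyond the scatter). Since compound 4 keeps its methoxy group and merely gains a larger aromatic substituent, a modest step toward a lower number or none beyond the scatter is expected in this assay, a 1.5-fold lower number from compound 1 to compound 4 (0.18 log units; within the scatter). For compound 4 the estimate is 6500 nM, in the range 2000 nM to 25000 nM.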

Compound 4, half-maximal inhibitory concentration: > 100000 nM
Compound 4 gave a limit, no number (the forecaster's own chance of this, stated with the estimate: 10%); at least 15-fold (1.18 log units) between middle value and limit.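

In this assay compound 4 gives > 100000 nM, a limit of the assay and not a number. Benzyloxy on this aromatic carbon, ortho to a methoxy group, gives an at least 10-fold higher number from compound 1 to compound 4 (1.01 log units; beyond the scatter), whereas enlarging the aryl group by another route, with naphthalen-2-yl in place of 4-methoxyphenyl, gave a 2.2-fold lower number from compound 1 to compound 3 (0.35 log units; beyond the scatter), so added aromatic size alone does not lower the number among these compounds. Compound 4 keeps the methoxy group that compound 2 lacks, yet the two end at the same limit: the limit of > 100000 nM in this assay, at which 2 of the 4 values shown sit.

How compound 2 and compound 4 rank against each other cannot be read from limits. On these data alone, it also stays open whether a hydroxyl, ethoxy or dimethylamino group on this carbon would leave the number near that of compound 1, or whether any substituent here raises it.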